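A few compounds are considered here, and "the series" means these few. Any claim that something is new, unique, unknown or untested is made for them only; others in the source may bear on it.

Compound 3 `C=CC(=O)N1CC(Oc2ccc(Oc3c(-c4ccc(F)cc4)sc4cc(O)ccc34)cc2)C1` belongs to a set of three compounds sharing a common core; its companions are compound 1 `O=C(/C=C/CNCCOc1ccc(Oc2c(-c3ccc(F)cc3)sc3cc(O)ccc23)cc1)N1CCCCC1` and compound 2 `O=C(/C=C/CNCCOc1ccc(Oc2c(-c3ccc(F)cc3)sc3cc(O)ccc23)cc1)N1CCCC1`. In a functional assay on Ishikawa cells (Homo sapiens) for antiproliferative activity, read by CCK-8 assay, with a stated time of 48 h (a higher number here means a weaker inhibitor, a lower number a stronger inhibitor), compound 1 gives 8430 nM, compound 2 gives 11300 nM, and compound 3 gives 12300 nM. Compound 3 thus carries the highest of the three numbers, but its distance from either companion is within the scatter, so the three compounds cannot be told apart on these data. Among the compounds with values here, the only measured step, a 1.3-fold higher number from compound 1 to compound 2 (0.13 log units; within the scatter), concerns the ring on the carbonyl carbon of the amide, not the chain carbon changed here, and it stays within the scatter.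

Compound 4 `C=C(C)C(=O)N1CC(Oc2ccc(Oc3c(-c4ccc(F)cc4)sc4cc(O)ccc34)cc2)C1` arises from compound 3 by the change (methyl in place of hydrogen on a double-bonded chain carbon bound to a carbonyl carbon). Within the data shown here, no measured pair shows what a methyl at that place does, and the one available step was flat, so no step beyond the scatter is expected from compound 3 to compound 4; the estimated step is a 1.1-fold higher number from compound 3 to compound 4 (0.02 log units; within the scatter). For compound 4 in this assay the expected value is 13000 nM, with a range from 5000 nM to 35000 nM.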

Compound 4, half-maximal inhibitory concentration: 14200 nM
Compound 4: middle estimate off by 1.1-fold (0.04 log units), on the low side; the measured number falls inside the stated range.
By their numbers in this assay, from the lowest: compounds 1, 2, 3 and 4 (each within the scatter of the next).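

In this assay, within the data shown here, the first measured pair at this place, methyl in place of hydrogen on a double-bonded chain carbon bound to a carbonyl carbon, gives a step within the scatter (a 1.2-fold higher number from compound 3 to compound 4 (0.06 log units; within the scatter)). Going from vinylcarbonyl to (1-methylethenyl)carbonyl therefore does not separate compound 3 from compound 4, whereas the earlier step concerned only the ring on the carbonyl carbon of a different chain. Nothing available offers an explanation for this flat step.

The compounds shown leave open whether a group other than methyl at this carbon, such as a dimethylaminomethyl amine or a carboxylic acid, would give a step beyond the scatter. They also leave open what a propanoyl group, with no double bond, would do in place of vinylcarbonyl.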